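An ethenyl chain gives way to an ethyl chain

The source may report more compounds than this note shows. Statements on the series, on what has been measured and on what is new or still open speak of the compounds shown alone.

In a functional assay on NAMALVA cells (Homo sapiens) for cytotoxicity, read by MTT assay, with a stated time of 72 h (a lower number here means a stronger inhibitor, a higher number a weaker inhibitor), compound 1 `COc1ccc(NC(=O)Nc2ccc(C(=O)NO)cc2)cc1` gives 4790 nM, compound 2 `COc1ccc(NC(=O)Nc2ccc(/C=C/C(=O)NO)cc2)cc1` gives 460 nM and compound 3 `O=C(/C=C/c1ccc(NC(=O)Nc2ccc([N+](=O)[O-])cc2)cc1)NO` gives 580 nM. Compound 3 thus sits within the scatter of compound 2, and well under compound 1. Compound 4 `O=C(CCc1ccc(NC(=O)Nc2ccc([N+](=O)[O-])cc2)cc1)NO` differs from it by 2-(hydroxycarbamoyl)ethyl in place of 2-(hydroxycarbamoyl)ethenyl on an aromatic carbon, with 2-(hydroxycarbamoyl)ethyl in place of 2-(hydroxycarbamoyl)ethenyl on an aromatic carbon. The large step of a 10-fold lower number from compound 1 to compound 2 (1.02 log units; beyond the scatter) is the only measured one that alters this chain, whereas the step of a 1.3-fold higher number from compound 2 to compound 3 (0.10 log units; within the scatter) concerns nitro in place of methoxy. Within the data shown here, no measured compound carries the ethyl chain, so a modest step of a 2.2-fold higher number from compound 3 to compound 4 (0.35 log units; beyond the scatter) toward a higher number is expected. For compound 4 the estimated value is 1300 nM, with an expected range of 500 nM to 3500 nM.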

Compound 4, half-maximal inhibitory concentration: 2500 nM
Estimate against measurement, compound 4: 1.9-fold (0.28 log units) below; the measured number falls inside the stated range.
By their numbers in this assay, from the lowest: compounds 2 and 3 (each within the scatter of the next); then compounds 4 and 1 (each within the scatter of the next).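

In this assay, saturating the chain at this position counts: 2-(hydroxycarbamoyl)ethyl in place of 2-(hydroxycarbamoyl)ethenyl gives a 4.3-fold higher number from compound 3 to compound 4 (0.63 log units; beyond the scatter). The earlier compounds shown here had varied this chain only by inserting the ethenyl unit, whereas here the heavy atoms stay the same in number and one double bond outside aromatic rings goes, and that alone moves the number beyond the scatter. Nothing available accounts for this rise.

Going by these compounds, it remains open whether a longer chain would recover or further weaken the value, and whether a carboxylic acid could stand in for the hydroxamic acid end. On these data alone, whether the methoxy partner, compound 2, responds to the same change also stays unknown.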